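A few compounds are considered here, and "the series" means these few. Any claim that something is new, unique, unknown or untested is made for them only; others in the source may bear on it.

Measured in an assay on HEK-293T cells for inhibition of phospholipase A and acyltransferase 4 (Homo sapiens), with stated times of 30 min and 20 min; a higher number here means a weaker inhibitor, a lower number a stronger inhibitor:

Compound 1 `O=C(CCc1ccc(Cl)cc1)C(=O)NCCCCc1ccccc1`: 1580 nM
Compound 2 `O=C(NCc1ccccc1)C(F)(F)C(O)CCc1ccccc1`: > 10000 nM, which is a limit of the assay and not a number (the limit of > 10000 nM in this assay, at which 1 of the 3 values shown sits).
Compound 3 `CCNC(=O)C(=O)CCc1ccc(Cl)cc1`: 3980 nM

Among the two numbers available, compound 3 stands highest; the step of a 2.5-fold higher number from compound 1 to compound 3 (0.40 log units; beyond the scatter) separates it from compound 1. Compound 4 `O=C(CCc1ccc(Cl)cc1)C(=O)N1CCCCC1` is not yet measured. It differs from compound 3 by piperidin-1-yl in place of ethylamino on a carbonyl carbon. For the measured compounds named here, no measured step touches the amide nitrogen substituent, so the only comparison available is the chain change from compound 1 to compound 3, which is of modest size; the present change is expected to stay within a similar size, direction uncertain, with a slight lean toward a lower number. Compound 4 is therefore expected to give about 3000 nM, between 800 nM and 12000 nM, i.e. an estimated step of a 1.3-fold lower number from compound 3 to compound 4 (0.12 log units; within the scatter).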

Compound 4, half-maximal inhibitory concentration: > 10000 nM
Compound 4 was reported as a limit; the forecaster's own chance of this, stated with the estimate: 15%; middle value at least 3.3-fold (0.52 log units) from the limit.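

Piperidin-1-yl in place of ethylamino on a carbonyl carbon gives an at least 2.5-fold higher number from compound 3 to compound 4 (0.40 log units; beyond the scatter) in this assay. For the compounds shown here, this is the first measured change at this amide substituent, and it removes the amide hydrogen while adding a six-membered ring, with weaker inhibition as the outcome. Compound 4 is a limit of the assay and not a number: the limit of > 10000 nM in this assay, at which 2 of the 4 values shown sit.

From the compounds shown here alone, it remains open whether the weakening follows the loss of the amide hydrogen or the ring. Dimethylamino and cyclohexylamino groups on the same carbonyl carbon would separate the two.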